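The source may hold more compounds than are shown below. What is called first, only, known or untested is meant among the compounds shown, and "the series" means these compounds.

Compound 1 `O=C(COc1cccc2ccccc12)N/N=C/c1cccc(O)c1`: 100 ug/mL
Compound 2 `O=C(COc1cccc2ccccc12)N/N=C/c1cccc(Cl)c1`: 100 ug/mL

In an ADME assay on HEL cells (Homo sapiens) for cytotoxicity (a higher number here means that more compound is tolerated, a lower number that less compound is tolerated), compound 2 gives 100 ug/mL, level with compound 1 at the digits shown. Going by the values given here, the one measured step, no change at the digits printed from compound 1 to compound 2 (within the scatter), stays within the scatter. Compound 3 `CSc1ccc(/C=N/NC(=O)COc2cccc3ccccc23)cc1` differs from compound 2 in a single place: 4-(methylsulfanyl)phenyl in place of 3-chlorophenyl on a carbon with a double bond to nitrogen. Among the compounds with values here, only that measured step bears on this change, and it showed no change beyond the scatter, so no step beyond the scatter is expected in this assay here either. Compound 3 is therefore expected to give about 100 ug/mL, between 50 ug/mL and 200 ug/mL, meaning an expected step of no change at the digits printed from compound 2 to compound 3 (within the scatter).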

Compound 3, minimum cytotoxic concentration in the HEL assay: >= 100 ug/mL
Compound 3: only a limit was reported; the forecaster's own chance of this, stated with the estimate: 60%; the middle value lies on the limit itself.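

In the HEL assay compound 3 carries >= 100 ug/mL, which is a limit of the assay and not a number. In the HEL assay the data show a number no lower from compound 2 to compound 3 (the limit leaves the size open), and a number no lower from compound 1 to compound 3 (the limit leaves the size open); the size of neither step can be read. In a physicochemical assay for lipophilicity, measured as octanol-water partition (on this read-out higher numbers stand for higher lipophilicity and lower numbers for lower lipophilicity), compound 2 gives 4.54 and compound 3 gives 4.11, a gap beyond the scatter, so this position has now taken a change in that read-out with no drop seen in tolerated concentration. Still open, from the compounds shown here alone, is where the true value of compound 3 lies in the HEL assay. Also open, going by these compounds, is how that assay would respond to an amine or a carboxylic acid in place of the methylsulfanyl group.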